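A few compounds are considered here, and "the series" means these few. Any claim that something is new, unique, unknown or untested is made for them only; others in the source may bear on it.

In a functional assay on SMMC-7721 cells (Homo sapiens) for antiproliferative activity, read by MTT assay, with a stated time of 72 h (a higher number here means a weaker inhibitor, a lower number a stronger inhibitor), measured so far:
- compound 1 `C/C(=N\NC(=O)c1cccc(S(=O)(=O)N2CCOCC2)c1)c1ccccc1O`: 1370 nM
- compound 2 `C/C(=N\NC(=O)c1cccc(S(=O)(=O)N2CCOCC2)c1)c1ccc(O)cc1`: 88500 nM

Compound 2 has the higher of the two numbers, and compound 1 is its nearest neighbour. Compound 3 `C/C(=N\NC(=O)c1cccc(S(=O)(=O)N2CCOCC2)c1)c1cc(Br)ccc1O` is still unmeasured. It differs from compound 2 on the carbon with a double bond to nitrogen: 5-bromo-2-hydroxyphenyl in place of 4-hydroxyphenyl on a carbon with a double bond to nitrogen. For the measured compounds named here, one measured step bears on this change: a 65-fold higher number from compound 1 to compound 2 (1.81 log units; beyond the scatter). That step is large and beyond the scatter. Read in reverse, it points to a much lower number for a compound carrying 5-bromo-2-hydroxyphenyl, as the hydroxyl placement of compound 1 returns. Going by the values given here, no measured step shows what the bromine does, so that part remains open. In this assay, a large downward step is expected: a 59-fold lower number from compound 2 to compound 3 (1.77 log units; beyond the scatter). Compound 3 is estimated at 1500 nM, with an expected range of 350 nM to 6500 nM.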

Compound 3, half-maximal inhibitory concentration: 2410 nM
Beside the measured number, compound 3's estimate is 1.6-fold (0.21 log units) below it; measured number inside the range.
By their numbers in this assay, from the lowest: compounds 1 and 3 (each within the scatter of the next); then compound 2.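

In this assay, 5-bromo-2-hydroxyphenyl on the carbon with a double bond to nitrogen brings the number far down from that of the 4-hydroxyphenyl compound (a 37-fold lower number from compound 2 to compound 3 (1.56 log units; beyond the scatter)). Bromo in place of hydrogen on an aromatic carbon leaves the number within the scatter (a 1.8-fold higher number from compound 1 to compound 3 (0.25 log units; within the scatter)), so the bromine is tolerated here, and among these three compounds the large gap separates compound 2 from the two 2-hydroxyphenyl-type compounds, compound 1 and compound 3. No data bearing on the cause of these differences are available.

Open, from the compounds shown here alone, is whether the hydroxyl itself is required, as a methoxy or amino group in its place would test. Also open, going by these compounds, is how this assay responds to other ring substituents, such as chloro or nitro, in place of the bromine.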